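This account rests on a few compounds, and the source may have more. Where it says the series, first, only, none or still open, it means among the compounds named here.

In a functional assay on HepG2 cells (Homo sapiens) for antiproliferative activity, read by MTT assay, with a stated time of 24 h (on this read-out lower numbers stand for stronger inhibition and higher numbers for weaker inhibition), compound 1 (`Cc1ccc(-c2nn(-c3ccccc3)cc2-c2nc3ccccc3[nH]2)cc1`) gives 6260 nM and compound 2 (`FC(F)(F)c1ccc(-c2nn(-c3ccccc3)cc2-c2nc3ccccc3[nH]2)cc1`) gives 6030 nM. These two share the top of the three numbers, and compound 3 (`O=[N+]([O-])c1ccc(S(=O)(=O)n2c(-c3cn(-c4ccccc4)nc3-c3ccc(F)cc3)nc3ccccc32)cc1`) lies clearly lower at 1340 nM. Compound 4 (`COc1ccc(S(=O)(=O)n2c(-c3cn(-c4ccccc4)nc3-c3ccc(C(F)(F)F)cc3)nc3ccccc32)cc1`) carries (4-methoxyphenyl)sulfonyl in place of hydrogen on an aromatic nitrogen of compound 2: (4-methoxyphenyl)sulfonyl in place of hydrogen on an aromatic nitrogen. Going by the values given here, the one measured step, a 1.0-fold lower number from compound 1 to compound 2 (0.02 log units; within the scatter), lies within the scatter and concerns another site, so it offers no guide to this change. Among the compounds with values here, the only hint is compound 3 at 1340 nM, which also bears a sulfonyl group on that nitrogen but differs elsewhere too. A moderate step toward a lower number is therefore expected, estimated as a 3.4-fold lower number from compound 2 to compound 4 (0.53 log units; beyond the scatter). Compound 4 is estimated at 1800 nM, with an expected range of 600 nM to 5500 nM.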

Compound 4, half-maximal inhibitory concentration: 370 nM
Compound 4: middle estimate off by 4.9-fold (0.69 log units), on the high side; measured number outside the range, below it.
By their numbers in this assay, from the lowest: compound 4; then compound 3; then compounds 2 and 1 (each within the scatter of the next).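

In this assay, (4-methoxyphenyl)sulfonyl in place of hydrogen on the aromatic nitrogen gives a 16-fold lower number from compound 2 to compound 4 (1.21 log units; beyond the scatter), a large step beyond the scatter. This shows that, unlike the site of the earlier measured step, this nitrogen is a place where a single change moves the number strongly. Nothing measured here explains the size of this step.

The compounds shown leave open whether the sulfonyl link or the 4-methoxyphenyl ring carries the step, and whether an acetyl or benzyl group on this nitrogen would do the same. On these data alone, whether the step also holds with the methyl group of compound 1 remains open too.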